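Benzyl for cyclohexyl on the shared core: an untested swap

The source may hold more compounds than are shown below. What is called first, only, known or untested is meant among the compounds shown, and "the series" means these compounds.

Measured so far in a functional assay on SK-MEL-28 cells (Homo sapiens) for inhibition, read by sulforhodamine B assay, with a stated time of 48 h, tested at 10 uM; on this read-out higher numbers stand for more inhibition at the one concentration tested (going by the name of the read-out) and lower numbers for less inhibition:
compound 1, `O=Cc1ccc(-c2cn3ccnc3c(-c3ccc4ncn(C5CCCCC5)c4c3)n2)cc1`, gives 7.54%;
compound 2, `Fc1ccc(-c2cn3ccnc3c(-c3ccc4ncn(C5CCCCC5)c4c3)n2)cc1`, gives 2.67%;
compound 3, `Brc1ccc(-c2cn3ccnc3c(-c3ccc4ncn(C5CCCCC5)c4c3)n2)cc1`, gives 28.3%.

Compound 1 sits second highest of the three numbers. Its nearest neighbour is compound 2, reached by a number 4.9 percentage points lower from compound 1 to compound 2 (within the scatter), which is within the scatter; its furthest is compound 3, reached by a number 20.8 percentage points higher from compound 1 to compound 3 (beyond the scatter), a modest step beyond the scatter. The step of a number 25.6 percentage points higher from compound 2 to compound 3 (beyond the scatter) is of the same kind.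

Compound 4, `O=Cc1ccc(-c2cn3ccnc3c(-c3ccc4ncn(Cc5ccccc5)c4c3)n2)cc1`, differs from compound 1 by benzyl in place of cyclohexyl on an aromatic nitrogen. Among the compounds with values here, all three measured steps vary the substituent on the outer aromatic carbon; none of them touches the group on the ring nitrogen, so no measured step bears directly on this change. With nothing shown for the cyclohexyl to benzyl swap, no step beyond the scatter is expected in this assay in either direction. Compound 4 is therefore estimated at 9%, with a range of -6% to 26%, which means an expected step of a number 1.5 percentage points higher from compound 1 to compound 4 (within the scatter).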

Compound 4, a percentage reported as inhibition, at one concentration (the size of the read-out at that concentration, not a potency): 7.54%
Beside the measured number, compound 4's estimate is 1.5 percentage points above it; the measured number falls inside the stated range.
By their numbers in this assay, from the lowest: compounds 2, 1 and 4 (each within the scatter of the next); then compound 3.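

In this assay, the group on the aromatic nitrogen now has its first measured step, with benzyl in place of cyclohexyl: no change at the digits printed from compound 1 to compound 4 (within the scatter). Within the data shown here, for this one pair, with the formyl group held fixed, exchanging a non-aromatic ring of carbon only for a benzyl group leaves the read-out flat, so the earlier picture of change arising only on the outer aromatic carbon gains a first matched comparison at the nitrogen. Nothing in the data available accounts for the absence of a change at this position.

Going by these compounds, whether the same swap stays as flat with bromo in place of formyl remains open, given the larger step of a number 20.8 percentage points higher from compound 1 to compound 3 (beyond the scatter) on the cyclohexyl series. Also open, on these data alone, is what an aminoethyl chain or a carboxylic acid on this ring nitrogen would do to the number.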